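Swapping the amide substituent of a kinase inhibitor

This account rests on a few compounds, and the source may have more. Where it says the series, first, only, none or still open, it means among the compounds named here.

Of the compounds shown here, two have been measured in an assay for inhibition of 6-phosphofructo-2-kinase/fructose-2,6-bisphosphatase 3 (Homo sapiens), read by ADP-Glo, with a stated time of 2 h; a higher number here means a weaker inhibitor, a lower number a stronger inhibitor. Compound 1, with the structure `Cn1ccc2ccc(-c3cc(Nc4ccccc4S(=O)(=O)Nc4cncnc4)cc4nccnc34)cc21`, gives 1690 nM. Compound 2, with the structure `Cn1cc(CNC(=O)c2ccncc2Nc2cc(-c3ccc4ccn(C)c4c3)c3nccnc3c2)cn1`, gives 159 nM. Of these two numbers, compound 2 has the lower one, and the gap between the two values is wider than the usual scatter of repeated measurements, so compound 2 is the stronger inhibitor of the pair.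

Compound 3, with the structure `CN1CC(NC(=O)c2ccncc2Nc2cc(-c3ccc4ccn(C)c4c3)c3nccnc3c2)C1`, has not yet been measured. It differs from compound 2 in one place: 1-methylazetidin-3-yl in place of (1-methyl-1H-pyrazol-4-yl)methyl on an amide-type nitrogen. Among the measured compounds shown here, no measured pair in this set shows what such a swap does, so the expectation for compound 3 rests only on the value of compound 2 in this assay. The amide group itself is kept, and the change is limited to the group on its nitrogen, so the step of a 1.9-fold higher number from compound 2 to compound 3 (0.28 log units; within the scatter) is estimated to be small, possibly a slight weakening, and may well stay within the scatter. For compound 3 in this assay the expected value is 300 nM, with a likely range from 100 nM to 1000 nM.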

Compound 3, half-maximal inhibitory concentration: 30 nM
Estimate against measurement, compound 3: 10-fold (1.00 log units) above, outside the stated range (below it).
By their numbers in this assay, from the lowest: compound 3; then compound 2; then compound 1.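

The group on the amide-type nitrogen clearly matters in this assay: with the rest of the molecule unchanged, putting 1-methylazetidin-3-yl in place of (1-methyl-1H-pyrazol-4-yl)methyl brings a 5.3-fold lower number from compound 2 to compound 3 (0.72 log units; beyond the scatter). Among the compounds shown here, this is the first comparison in the set that differs in only one place, and it shows that this position can shift the measured inhibition, which the earlier pair, differing in more than one place, could not show. It also shows that a smaller group, a four-membered non-aromatic ring in place of a five-membered aromatic ring, can stand here with a stronger inhibitor as the result, although no measurement shown bears on why the number falls.

This single swap changes the ring size, the aromatic character and the way the ring is joined to the amide nitrogen all at once, and one step cannot say which of these changes counts. A 1-methylpiperidin-4-yl group or an azetidin-3-yl group without the methyl, placed on the same nitrogen, would help to separate these features.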